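The compounds below may be only part of what the source reports. "The series", "measured", "known", "first", "only" and "open" are said of these compounds alone.

Measured so far in a functional assay on aorta (Rattus norvegicus, strain Wistar); on this read-out lower numbers stand for stronger inhibition and higher numbers for weaker inhibition:
- compound 1 `Cc1ccc2c(c1)N(C1=CCCC1=O)CC(C)(C)S2` gives 933 nM
- compound 2 `CC(=O)c1ccc2c(c1)N(C1=CCCC1=O)CC(C)(C)S2` gives 1.45 nM

Compound 2 stands lowest of the two numbers. Next is compound 3 `CC(=O)Nc1ccc2c(c1)N(C1=CCCC1=O)CC(C)(C)S2` with acetamido in place of acetyl on an aromatic carbon as the change. Among the measured compounds shown here, the only measured step that bears on it is a 640-fold lower number from compound 1 to compound 2 (2.81 log units; beyond the scatter) and it is large, with acetyl in place of methyl. For the measured compounds named here, no measured compound carries acetamido. A step to a higher number is expected in this assay and is estimated as a 41-fold higher number from compound 2 to compound 3 (1.62 log units; beyond the scatter) in size, smaller than the measured one. The estimate for compound 3 is 60 nM with an expected range from 8 nM to 450 nM in this series.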

Compound 3, half-maximal inhibitory concentration: 6610 nM
Compound 3: middle estimate off by 110-fold (2.04 log units), on the low side, outside the stated range (above it).
By their numbers in this assay, from the lowest: compound 2; then compound 1; then compound 3.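

In this assay, acetamido in place of acetyl on the same aromatic carbon gives a 4600-fold higher number from compound 2 to compound 3 (3.66 log units; beyond the scatter), so a carbonyl-bearing group here does not by itself secure a low number. Acetamido also falls behind plain methyl, with a 7.1-fold higher number from compound 1 to compound 3 (0.85 log units; beyond the scatter), which orders this position as acetyl, then methyl, then acetamido. Nothing available explains this order.

The compounds shown leave open whether the low number of compound 2 is particular to acetyl or extends to a propanoyl group, a methyl ester or a nitrile at this carbon.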